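From compound 1 to compound 4: chloro for fluoro

The compounds below may be only part of what the source reports. "The series", "measured", "known", "first", "only" and "open" are said of these compounds alone.

In an ADME assay on PBMC cells (Homo sapiens) for cytotoxicity, with a stated time of 5 days (a lower number here means a stronger inhibitor, a higher number a weaker inhibitor), compound 1 (`COc1nc(F)nc2c1ncn2[C@H]1C[C@H](N=[N+]=[N-])[C@@H](CO)O1`) gives 9400 nM and compound 3 (`[N-]=[N+]=N[C@H]1C[C@H](n2cnc3c(Cl)nc(F)nc32)O[C@@H]1CO`) gives 7200 nM. Within the data shown here, these are the only two numbers so far, and they cannot be told apart: the step is a 1.3-fold lower number from compound 1 to compound 3 (0.12 log units; within the scatter). Compound 2 (`C#CCNc1nc(N)nc2c1ncn2[C@H]1C[C@H](N=[N+]=[N-])[C@@H](CO)O1`) reads > 100000 nM, which is a limit of the assay and not a number.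

The next compound to be read is compound 4 (`COc1nc(Cl)nc2c1ncn2[C@H]1C[C@H](N=[N+]=[N-])[C@@H](CO)O1`). Relative to compound 1, the change is chloro in place of fluoro on an aromatic carbon. In words, chloro replaces fluoro on an aromatic carbon between two ring nitrogen atoms, and the methoxy group stays.

Among the measured compounds shown here, no measured step exchanges fluoro for chloro. The closest guide is the step to compound 3, where chloro replaces methoxy on an aromatic carbon and the result stays within the scatter: a 1.3-fold lower number from compound 1 to compound 3 (0.12 log units; within the scatter). That single step is thin support, and it concerns a different leaving group. Even so, it gives no reason to expect a shift beyond the scatter in this assay, in either direction. The expected step is a 1.1-fold higher number from compound 1 to compound 4 (0.03 log units; within the scatter), which is no real change. For compound 4 the estimated value is 10000 nM, with an expected range of 3500 nM to 35000 nM.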

Compound 4, half-maximal inhibitory concentration: > 100000 nM
Compound 4 was reported as a limit (the forecaster's own chance of this, stated with the estimate: 15%); at least 10-fold (1.00 log units) between middle value and limit.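

In this assay, the aromatic carbon between two ring nitrogen atoms proves sensitive to the identity of its halogen, with the methoxy group unchanged: an at least 10-fold higher number from compound 1 to compound 4 (1.02 log units; beyond the scatter). The only earlier single-place change, chloro in place of methoxy on an aromatic carbon, stayed within the scatter (a 1.3-fold lower number from compound 1 to compound 3 (0.12 log units; within the scatter)), so the shared core had not previously shown that one exchange of a single heavy atom could move the read-out this far. The value of compound 4, > 100000 nM, is a limit of the assay and not a number, so the step fixes only a minimum size and the full effect of chloro at this carbon remains unmeasured here: the limit of > 100000 nM in this assay, at which 2 of the 4 values shown sit.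

The compounds shown leave open whether the shift is specific to chloro or would also follow from bromo or a hydroxyl group at this carbon. They also leave open whether chloro for fluoro gives a step of similar size when an ethoxy group or a longer alkoxy chain takes the place of the methoxy group.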